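From furan-2-yl to furan-3-yl at the assay limit

The compounds below may be only part of what the source reports. "The series", "measured", "known", "first", "only" and "open" are said of these compounds alone.

Measured compounds in a functional assay on P388 cells (Mus musculus) for inhibition; a higher number here means a weaker inhibitor, a lower number a stronger inhibitor
Compound 1 `FC(F)(F)Oc1ccc(/C=C/c2ccc3ccccc3c2)cc1` gives > 5000 nM
Compound 2 `C(=C/c1ccco1)\c1ccc2ccccc2c1` gives > 5000 nM
Compound 3 `C(=C\c1ccco1)\c1ccc2ccccc2c1` gives > 5000 nM

In this assay compound 2 stands at > 5000 nM, which is a limit and not a number. The series as a whole offers no number either, only (the limit of > 5000 nM in this assay, at which 3 of the 3 values shown sit).

Compound 4 `C(=C/c1ccc2ccccc2c1)\c1ccoc1` has not yet been measured. It has furan-3-yl in place of furan-2-yl on a double-bonded chain carbon bound to a double-bonded chain carbon.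

For the measured compounds named here, the only measured step near this change is a step that the two limits leave unreadable from compound 2 to compound 3. It reflects (the fact that compounds 2 and 3 differ only in the configuration as drawn), so it does not speak to the furan attachment, and its size cannot be read. The data therefore give no direction for the change, and no step beyond the scatter is expected in this assay. The expected step is a step that the limit leaves unreadable from compound 2 to compound 4. For compound 4 the estimated value is 7000 nM, with an expected range of 3000 nM to 20000 nM.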

Compound 4, half-maximal inhibitory concentration: > 5000 nM
Compound 4: only a limit was reported; the forecaster's own chance of this, stated with the estimate: 85%; the middle value is on the limit's open side.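

In this assay compound 4 gives > 5000 nM, which is a limit and not a number. For the compounds shown here, compound 2 also stands at a limit, so no step from furan-2-yl to furan-3-yl can be read between compound 2 and compound 4. The compounds shown leave open whether the furan attachment changes inhibition at all, and how strong any of them is: the limit of > 5000 nM in this assay, at which 4 of the 4 values shown sit.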